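Tolerance of compound 3 in MOLT-3 cells

This account rests on a few compounds, and the source may have more. Where it says the series, first, only, none or still open, it means among the compounds named here.

Values measured in an ADME assay on MOLT-3 cells (Homo sapiens) for cytotoxicity, with a stated time of 7 days (a higher number here means that more compound is tolerated, a lower number that less compound is tolerated), are these
compound 1 `CNc1nc(N)nc2c1ncn2/C=C1/CC1(CO)CO` gives > 20000 nM
compound 2 `Nc1nc(NC2CCCCC2)c2ncn(/C=C3/CC3(CO)CO)c2n1` gives "not determined" (no result reported)

Compound 2 has no number to start from, since its entry in this assay reads "not determined" (no result reported) and nothing more. Going by the values given here, the only firm reading for the series is therefore that of compound 1. Compound 1 stands at a limit of the assay (> 20000 nM), and this is a limit, not a number. The evidence so far amounts to the limit of > 20000 nM in this assay, at which 1 of the 2 values shown sits, and no more.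

Compound 3 `CSc1nc(N)nc2c1ncn2/C=C1/CC1(CO)CO` has not yet been measured. The structural change is methylsulfanyl in place of cyclohexylamino on an aromatic carbon and it places methylsulfanyl in place of cyclohexylamino on an aromatic carbon of a six-membered aromatic ring with 2 nitrogen.

Among the compounds with values here, no measured step bears on this change, so the expectation is modest. Compound 3 is expected to lie close to the limit seen for the series, with no step beyond the scatter in either direction, and it may well be reported as a limit too. The estimated value for compound 3 is 20000 nM in the middle, with an expected range from 6000 nM to 60000 nM for the measurement.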

Compound 3, half-maximal cytotoxic concentration: > 20000 nM
Compound 3: a limit, no number; the forecaster's own chance of this, stated with the estimate: 65%; the middle value lies on the limit itself.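

In this assay, going by these compounds alone, compound 3 gives a limit and not a number, as compound 1 does, so no step between compound 1 and compound 3 can be read. The compounds shown leave open whether methylsulfanyl and methylamino differ at all in how much compound is tolerated, for the series offers only this: the limit of > 20000 nM in this assay, at which 2 of the 3 values shown sit.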